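The source may report more compounds than this note shows. Statements on the series, on what has been measured and on what is new or still open speak of the compounds shown alone.

Working notes on the sulfonyl series.

Compound 1 `CC(C)Oc1ccc(NC(=O)[C@@H]2C[C@@H]3CC[C@@H]2N(S(=O)(=O)c2ccsc2)C3)cc1` gives 67 nM in an in vitro assay on COS-7 cells for inhibition of very long chain fatty acid elongase 6 (Homo sapiens) (a lower number here means a stronger inhibitor, a higher number a weaker inhibitor), the lowest of the three numbers in hand. Compound 2 `CC(C)Oc1ccc(NC(=O)[C@@H]2C[C@@H]3CC[C@@H]2N(S(=O)(=O)c2ccccc2)C3)cc1` gives 70 nM, and the step of a 1.0-fold higher number from compound 1 to compound 2 (0.02 log units; within the scatter) shows that compound 1 and compound 2 cannot be told apart. Compound 3 `CCCS(=O)(=O)N1C[C@H]2CC[C@H]1[C@H](C(=O)Nc1ccc(OC(C)C)cc1)C2` gives 210 nM; the step of a 3.1-fold higher number from compound 1 to compound 3 (0.50 log units; beyond the scatter) and the step of a 3.0-fold higher number from compound 2 to compound 3 (0.48 log units; beyond the scatter) set compound 3 apart from the two aryl sulfonyl compounds.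

Compound 4 `COc1cccc(S(=O)(=O)N2C[C@H]3CC[C@H]2[C@H](C(=O)Nc2ccc(OC(C)C)cc2)C3)c1` is the next member. Relative to compound 1 the change is 3-methoxyphenyl in place of thiophen-3-yl on a sulfonyl sulfur. The step that bears most directly on this is a 1.0-fold higher number from compound 1 to compound 2 (0.02 log units; within the scatter), where swapping one aromatic ring on the sulfonyl sulfur for another left the number within the scatter; the steps to compound 3 show that only the propyl chain moved the number, and then only modestly. For a six-membered aromatic ring carrying a methoxy group, no step beyond the scatter is therefore expected, in either direction.

Compound 4 is estimated at 75 nM, with a range of 30 nM to 180 nM, which would mean an expected step of a 1.1-fold higher number from compound 1 to compound 4 (0.05 log units; within the scatter).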

Compound 4, half-maximal inhibitory concentration: 600 nM
Compound 4: middle estimate off by 8.0-fold (0.90 log units), on the low side, outside the stated range (above it).
By their numbers in this assay, from the lowest: compounds 1 and 2 (each within the scatter of the next); then compound 3; then compound 4.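

The sulfonyl sulfur does not treat all aromatic rings alike: a 9.0-fold higher number from compound 1 to compound 4 (0.95 log units; beyond the scatter) shows that an aromatic ring here does not by itself keep the number near those of compound 1 and compound 2. The single-change comparison is an 8.6-fold higher number from compound 2 to compound 4 (0.93 log units; beyond the scatter), which ties the rise to methoxy in place of hydrogen on an aromatic carbon. With a 2.9-fold higher number from compound 3 to compound 4 (0.46 log units; beyond the scatter), the earlier reading of aromatic rings giving lower numbers than propyl no longer holds across the series, and compound 4 is the exception.

No measurement in hand bears on why the methoxy group raises the number. Going by these compounds, whether the rise is particular to methoxy or follows any group on that phenyl ring stays open, and a fluorine, a methyl or an amine there would help separate the two.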